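Swapping a Nitrogen Methyl for Hydrogen Across Two Cores

The source may hold more compounds than are shown below. What is called first, only, known or untested is meant among the compounds shown, and "the series" means these compounds.

Of the compounds shown here, three have been measured in a functional assay on PA-1 cells (Homo sapiens) for cytotoxicity, read by MTT assay, with stated times of 6 h and 48 h; on this read-out lower numbers stand for stronger inhibition and higher numbers for weaker inhibition. Compound 1 `COc1ccc(OC)c(C(=O)/C=C/c2cc(Br)c(Br)n2C)c1` gives 800 nM in this assay. Compound 2 `COc1ccc(OC)c(C(=O)/C=C/c2cc(Br)c(Br)[nH]2)c1` differs from compound 1 by hydrogen in place of methyl on an aromatic nitrogen, and in this assay compound 2 gives 420 nM. This change made a 1.9-fold lower number from compound 1 to compound 2 (0.28 log units; within the scatter), so the two compounds cannot be told apart on this read-out.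

Compound 3 `Cn1c(-c2cc(-c3ccccc3O)no2)cc(Br)c1Br` is built on a different core; how the core of compound 3 differs from the core of compound 1 is not broken down here. In this assay compound 3 reaches only a limit of the assay, >= 100000 nM, and no number.

Compound 4 `Oc1ccccc1-c1cc(-c2cc(Br)c(Br)[nH]2)on1` has not yet been measured. It differs from compound 3 by hydrogen in place of methyl on an aromatic nitrogen, the same change that separates compound 1 from compound 2, at a place described in the same words. A step of about the same small size is expected from compound 3 to compound 4, a number no higher from compound 3 to compound 4 (the limit leaves the size open), because a 1.9-fold lower number from compound 1 to compound 2 (0.28 log units; within the scatter) is what this change produced on the core of compound 1. Compound 3 sits at the limit of >= 100000 nM in this assay, at which 1 of the 3 values shown sits. Compound 4 is therefore expected to give 100000 nM in this assay, most likely reported once more only as a limit, with an expected range from 30000 nM to 300000 nM.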

Compound 4, half-maximal inhibitory concentration: >= 100000 nM
Compound 4 ended at the assay's limit; the forecaster's own chance of this, stated with the estimate: 80%; the middle value sits exactly at the limit.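

Compound 3 and compound 4 both reach only a limit of the assay rather than a number, so no step between them can be read: the limit of >= 100000 nM in this assay, at which 2 of the 4 values shown sit.

The compounds shown leave open whether hydrogen in place of methyl on the aromatic nitrogen changes anything on the core of compound 3, and how strongly, if at all, either compound inhibits in this assay.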